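Ester variation on the pyrimidinone core: metabolic stability

The source may hold more compounds than are shown below. What is called first, only, known or untested is meant among the compounds shown, and "the series" means these compounds.

In an ADME assay on microsomes from liver (Homo sapiens) for metabolic stability, with a stated time of 30 min (a higher number here means that more of the compound is left, a lower number that less of the compound is left), compound 2 `CC#CCOC(=O)Cc1c(C(C)C)nc(CCCC)n(Cc2ccc(-c3ccccc3-c3noc(=O)[nH]3)cc2)c1=O` gives 13.7%. Compound 1 `CCCCCOC(=O)Cc1c(C(C)C)nc(CCCC)n(Cc2ccc(-c3ccccc3-c3noc(=O)[nH]3)cc2)c1=O` gives 10.6% in this assay, and the step of a number 3.1 percentage points higher from compound 1 to compound 2 (within the scatter) does not separate the two; both numbers are low. Compound 3 `CCCCc1nc(C(C)C)c(C(C)C(=O)OCC)c(=O)n1Cc1ccc(-c2ccccc2-c2noc(=O)[nH]2)cc1` is the next member and is not yet measured. It differs from compound 2 as follows: 1-(ethoxycarbonyl)ethyl in place of (((but-2-yn-1-yl)oxy)carbonyl)methyl on an aromatic carbon. Among the measured compounds shown here, only one measured step bears on this change, that from compound 1 to compound 2, which also exchanged the alkyl part of the ester at the same position and came out within the scatter. For the measured compounds named here, the change to compound 3 touches both the alkyl part of the ester and the chain carbon bound to the aromatic ring, for which no measured step exists. The expected step of a number 0.3 percentage points higher from compound 2 to compound 3 (within the scatter) is therefore set at about nothing beyond the scatter, because a number 3.1 percentage points higher from compound 1 to compound 2 (within the scatter) was within it. Compound 3 is estimated at 14%, with a range from 4% to 30%.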

Compound 3, percent of the compound remaining: 11%
The estimate for compound 3 lay 3 percentage points above the measured number; low and high end bracket the measured number.
By their numbers in this assay, from the lowest: compounds 1, 3 and 2 (each within the scatter of the next).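

In this assay the step of a number 2.7 percentage points lower from compound 2 to compound 3 (within the scatter) and the step of a number 0.4 percentage points higher from compound 1 to compound 3 (within the scatter) both stay within the scatter, and 1-(ethoxycarbonyl)ethyl on this aromatic carbon cannot be told apart from either earlier ester chain. Among the compounds shown here, this is the first change that reaches the chain carbon bound to the aromatic ring as well as the alkyl part of the ester, and even this double change leaves the number low. No measurement on hand explains the low numbers.

As far as these compounds go, how much each part of the change contributes alone remains open, as the two parts occur only together here. Also open, from the compounds shown here alone, is whether any group at this position gives a clearly higher number, for example a carboxylic acid or an amide in place of the ester.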